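The source may report more compounds than this note shows. Statements on the series, on what has been measured and on what is new or still open speak of the compounds shown alone.

Compound 3 `CCC(CC)(c1ccc(OCC(=O)O)c(C)c1)c1ccc(OCC(O)C(C)(C)C)c(OCC(O)C(C)(C)C)c1` gives 10% in an assay on cells for binding affinity to vitamin D3 receptor (Homo sapiens), read by fluorescence, tested at 1 uM (on this read-out higher numbers stand for more inhibition at the one concentration tested (going by the name of the read-out) and lower numbers for less inhibition), the lowest of the three numbers measured. Compound 2 `CCC(CC)(c1ccc(OCCCCCCO)c(C)c1)c1ccc(OCC(O)C(C)(C)C)c(OCC(O)C(C)(C)C)c1` gives 52% in this assay, and compound 1 `CCC(CC)(c1ccc(OS(=O)(=O)c2ccc(C)cc2)c(C)c1)c1ccc(OCC(=O)C(C)(C)C)c(OCC(=O)C(C)(C)C)c1` gives 35%. Among the compounds with values here, the one single-point step among the measured compounds runs a number 42 percentage points lower from compound 2 to compound 3 (beyond the scatter), so the carboxymethyl group in compound 3 goes with a clearly weaker read-out than the 5-hydroxypentyl chain of compound 2.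

Compound 4 `CCC(CC)(c1ccc(OS(=O)(=O)c2ccc([N+](=O)[O-])cc2)c(C)c1)c1ccc(OCC(O)C(C)(C)C)c(OCC(O)C(C)(C)C)c1` is compound 3 with (4-nitrophenyl)sulfonyl in place of carboxymethyl on an oxygen on an aromatic ring. Within the data shown here, no measured pair mirrors this exact change; the nearest guide is compound 1, which carries a sulfonyl ester on the same oxygen and gives 35%. The same two hydroxy side chains as in compound 4 are carried by compound 2, which gives 52%. Since both neighbours without the carboxymethyl group sit well above compound 3, a rise beyond the scatter is expected for compound 4, estimated as a number 30 percentage points higher from compound 3 to compound 4 (beyond the scatter). Compound 4 is therefore expected to reach about 40% in this assay, with a range from 15% to 65%.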

Compound 4, a percentage reported as inhibition, at one concentration (the size of the read-out at that concentration, not a potency): 29%
Beside the measured number, compound 4's estimate is 11 percentage points above it; the range from low to high includes it.
By their numbers in this assay, from the lowest: compound 3; then compounds 4 and 1 (each within the scatter of the next); then compound 2.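

In this assay, (4-nitrophenyl)sulfonyl in place of carboxymethyl on an oxygen on an aromatic ring gives a number 19 percentage points higher from compound 3 to compound 4 (beyond the scatter), so a sulfonyl group bearing an aromatic ring reads above carboxymethyl at this position. Set against the chain, the same group gives a number 23 percentage points lower from compound 2 to compound 4 (beyond the scatter), which puts the three groups on this oxygen in an order with every gap beyond the scatter: carboxymethyl lowest, (4-nitrophenyl)sulfonyl in the middle and 6-hydroxyhexyl highest. No supporting data are available to explain this order.

The compounds shown leave open whether the higher number of the 6-hydroxyhexyl compound depends on the chain or on its terminal hydroxy group, which a plain hexyl chain would test. They also leave open how a hexyl chain ending in an amine or a carboxylic acid would read on this oxygen.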